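Trifluoromethoxy in Place of Methyl on the Anilino Ring

A few compounds are considered here, and "the series" means these few. Any claim that something is new, unique, unknown or untested is made for them only; others in the source may bear on it.

In a functional assay on NCI-H460 cells (Homo sapiens) for antiproliferative activity, read by CCK-8 assay, with a stated time of 72 h, tested at 8 uM (on this read-out lower numbers stand for a weaker effect and higher numbers for a stronger effect at the one concentration tested), compound 3 `Cc1ccc(Nc2nc(Cl)nc3c2ncn3Cc2ccc(/C=C/C(=O)Nc3ccccc3N)cc2)cc1` gives 51.3%, the second highest of three numbers. Compound 2 `Nc1ccccc1NC(=O)c1ccc(Cn2cnc3c(Nc4cccc(OC(F)(F)F)c4)nc(Cl)nc32)cc1` gives 62.4%, and compound 1 `Nc1ccccc1NC(=O)/C=C/c1ccc(Cn2cnc3c(Nc4ccccc4)nc(Cl)nc32)cc1` gives 28.7%. Compound 4 `Nc1ccccc1NC(=O)/C=C/c1ccc(Cn2cnc3c(Nc4cccc(OC(F)(F)F)c4)nc(Cl)nc32)cc1` differs from compound 3 in one place: 3-(trifluoromethoxy)phenyl in place of 4-methylphenyl on a nitrogen on an aromatic ring. Going by the values given here, the one step that bears on this position is a number 22.6 percentage points higher from compound 1 to compound 3 (beyond the scatter), which shows that a group on this ring changes the read-out. Compound 2 carries the same trifluoromethoxyphenyl group on a different linker and stands higher than compound 3, so a modest rise is expected, a number 6.7 percentage points higher from compound 3 to compound 4 (within the scatter). Compound 4 is therefore estimated at 58%, within 42% to 74%.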

Compound 4, a percentage reported as inhibition, at one concentration (the size of the read-out at that concentration, not a potency): 66.7%
For compound 4 the middle estimate is 8.7 percentage points below the measured one; the range from low to high includes it.
By their numbers in this assay, from the lowest: compound 1; then compound 3; then compounds 2 and 4 (each within the scatter of the next).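

In this assay, the exchange of 4-methylphenyl for 3-(trifluoromethoxy)phenyl on the nitrogen proves to be a step beyond the scatter on the cinnamide-free reading of this ring alone (a number 15.4 percentage points higher from compound 3 to compound 4 (beyond the scatter)), and trifluoromethoxy in place of hydrogen gives a large step (a number 38 percentage points higher from compound 1 to compound 4 (beyond the scatter)). The linker change stays within the scatter (a number 4.3 percentage points higher from compound 2 to compound 4 (within the scatter)), so with this group on the nitrogen the two linkers cannot be told apart. The compounds shown do not separate the trifluoromethoxy group from its place on the ring, and they leave open how an amine or a carboxylic acid on this ring would read. No measurement here explains these steps.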